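Swapping Trifluoromethyl for Methyl in Compound 2

This account rests on a few compounds, and the source may have more. Where it says the series, first, only, none or still open, it means among the compounds named here.

- Compound 1 `CCC/N=C1\S/C(=C\c2ccc(O)c(Cl)c2)C(=O)N1C1CCS(=O)(=O)CC1`: 75000 nM
- Compound 2 `CCC/N=C1\S/C(=C\c2ccc(O)c(C(F)(F)F)c2)C(=O)N1c1ccccc1C`: 14000 nM
- Compound 3 `CCC/N=C1\S/C(=C\c2ccc(O)c(Cl)c2)C(=O)N1C(C)C`: 20000 nM

In a physicochemical assay for solubility, measured as kinetic solubility (a lower number here means a less soluble compound, a higher number a more soluble compound), compound 2 gives 14000 nM, which lies within the usual scatter of compound 3 at 20000 nM. Compound 1 stands clearly higher at 75000 nM.

Compound 4 `CCC/N=C1\S/C(=C\c2ccc(O)c(C)c2)C(=O)N1c1ccccc1C` has not yet been measured. It differs from compound 2 by having methyl in place of trifluoromethyl on an aromatic carbon, ortho to a hydroxy group: methyl in place of trifluoromethyl on an aromatic carbon.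

Among the compounds with values here, no measured pair makes this exchange, so the data offer no direct guide. Within the data shown here, the one measured step, a 3.8-fold lower number from compound 1 to compound 3 (0.57 log units; beyond the scatter), is modest and concerns a different place, where isopropyl replaces 1,1-dioxothian-4-yl on an amide-type nitrogen in a ring. It shows only how large a single change can be in this assay. No step beyond the scatter is therefore expected, and either direction remains possible.

The expected change is a 1.2-fold lower number from compound 2 to compound 4 (0.07 log units; within the scatter). The estimate for compound 4 is 12000 nM. The expected range for compound 4 runs from 4000 nM to 35000 nM.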

Compound 4, solubility: 78000 nM
Compound 4: middle estimate off by 6.5-fold (0.81 log units), on the low side; the measured number lies above the stated range.
By their numbers in this assay, from the lowest: compounds 2 and 3 (each within the scatter of the next); then compounds 1 and 4 (each within the scatter of the next).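

In this assay, the aromatic carbon ortho to a hydroxy group proves to be a place where one exchange counts: methyl in place of trifluoromethyl gives a 5.6-fold higher number from compound 2 to compound 4 (0.75 log units; beyond the scatter) and moves the number beyond the scatter. Within the data shown here, the earlier compounds offered a measured step only at the amide-type nitrogen, so this is the first sign that a change on the aromatic ring alone can matter, with methyl carrying the higher number of this pair. No measurement at hand gives a reason for this step.

The compounds shown leave open how an amine, a methoxy group or a nitrile would read on this same carbon. They also leave open whether this exchange gives a step of similar size when isopropyl sits on the amide-type nitrogen.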